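A few compounds are considered here, and "the series" means these few. Any claim that something is new, unique, unknown or untested is made for them only; others in the source may bear on it.

Compound 1, `Cc1ccccc1-n1ncc2c(=O)n(-c3ccc(Cl)cc3)c(C)nc21`, in an in vitro functional assay on cells for antagonist activity at metabotropic glutamate receptor 5 (Homo sapiens), read by FLIPR and calcium flux (a higher number here means a weaker inhibitor, a lower number a stronger inhibitor), gives 9500 nM.
Compound 2, `Cc1cccc(-n2ncc3c(=O)n(-c4ccc(Cl)cc4)c(C)nc32)c1`, in this assay gives > 100000 nM, which is a limit of the assay and not a number.
Compound 3, `Cc1nc2c(cnn2-c2ccc(Cl)cc2)c(=O)n1-c1ccc(Cl)cc1`, in this assay gives > 100000 nM, again a limit of the assay rather than a number.

Compound 3 thus stands where the assay reports only a limit for it (the limit of > 100000 nM in this assay, at which 2 of the 3 values shown sit). Only compound 1 gives a readable number, and both changes made from it on the aromatic nitrogen cost activity: an at least 10-fold higher number from compound 1 to compound 2 (1.02 log units; beyond the scatter), and an at least 10-fold higher number from compound 1 to compound 3 (1.02 log units; beyond the scatter). Between compound 2 and compound 3 the step is a step that the two limits leave unreadable from compound 2 to compound 3.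

Compound 4, `Cc1nc2c(cnn2-c2cncnc2)c(=O)n1-c1ccc(Cl)cc1`, is the compound not yet measured. It differs from compound 3 in one place: pyrimidin-5-yl in place of 4-chlorophenyl on an aromatic nitrogen. Every measured step concerns the group on this same aromatic nitrogen, and the two readable ones were large losses. Nothing measured shows what a pyrimidin-5-yl group does at this position, and compound 3, the starting point, already sits at the limit, where a further loss cannot be read. The expectation for compound 4 is that it stays close to compound 3, with a number no higher from compound 3 to compound 4 (the limit leaves the size open) expected to be small or not readable. Compound 4 is estimated at 100000 nM, in the range from 30000 nM to 300000 nM, most likely reported once more as a limit.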

Compound 4, half-maximal inhibitory concentration: > 100000 nM
Compound 4: no number, only a limit (the forecaster's own chance of this, stated with the estimate: 70%); the middle value lies on the limit itself.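

Compound 4 joins the compounds that sit at the upper end of what this assay can report, so its value is a limit and not a number: the limit of > 100000 nM in this assay, at which 3 of the 4 values shown sit. Set against compound 1, the only compound with a readable value, the pyrimidin-5-yl group is a large loss: an at least 10-fold higher number from compound 1 to compound 4 (1.02 log units; beyond the scatter). This adds a ring with hetero atoms to the groups tried on this aromatic nitrogen, and like the carbon-only rings 3-methylphenyl and 4-chlorophenyl it gives no readable number, leaving 2-methylphenyl as the only group shown that does. The steps among compound 2, compound 3 and compound 4 cannot be read, so these three groups cannot be put in any order.

The compounds shown leave open whether the readable value of compound 1 depends on the methyl group of its 2-methylphenyl ring, a question that plain phenyl or 2-methoxyphenyl on the same nitrogen would address. They also leave open whether a ring with hetero atoms could give a readable number if it carried a methyl group, as 2-methylpyridin-3-yl does.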